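Cyclohexyl for phenyl on compound 2

The source may hold more compounds than are shown below. What is called first, only, known or untested is meant among the compounds shown, and "the series" means these compounds.

In a toxicity assay on THP-1 cells (Homo sapiens) for inhibition (on this read-out lower numbers stand for higher toxicity in this test and higher numbers for lower toxicity in this test), compound 1 (`O=C(Nc1ncc(-c2ccccc2)o1)c1ccc(Cl)cc1`) gives 10000 nM. Compound 2 (`Cn1c(-c2ccccc2)cnc1NC(=O)c1ccccc1`) stands only at a limit, > 100000 nM. Compound 3 (`COc1ccc(-c2cnc(NC(=O)c3ccccc3)n2C)cc1`) also gives only a limit, > 100000 nM. Compound 4 (`Cn1c(-c2ccccc2)cnc1NC(=O)C1CCCCC1`) has cyclohexyl in place of phenyl on a carbonyl carbon. The only measured step among these compounds is a step that the two limits leave unreadable from compound 2 to compound 3, and it concerns a different change. The closest guide in this assay is the limit of > 100000 nM in this assay, at which 2 of the 3 values shown sit. Among the compounds with values here, with no sized step to draw on, no change beyond the scatter is expected, and the estimated step is a number no higher from compound 2 to compound 4 (the limit leaves the size open). Compound 4 is expected near 100000 nM, with an estimated range of 30000 nM to 200000 nM.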

Compound 4, half-maximal cytotoxic concentration: > 100000 nM
Compound 4 gave a limit, no number; the forecaster's own chance of this, stated with the estimate: 70%; the middle value lies on the limit itself.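

Within the data shown here, compound 2 and compound 4 both stand only at a limit in this assay, so no step between them can be read. The compounds shown leave open whether cyclohexyl in place of phenyl on a carbonyl carbon changes the read-out at all.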